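From fluoro to trifluoromethyl on compound 2

A few compounds are considered here, and "the series" means these few. Any claim that something is new, unique, unknown or untested is made for them only; others in the source may bear on it.

- compound 1 `CN(C)C(=O)c1cc2cnc(Nc3ccc(N)cn3)nc2n1C1CCCC1`: 61.1%
- compound 2 `CN(C)C(=O)c1cc2cnc(Nc3ccc(NC(=O)C4(C(=O)Nc5cccc(F)c5)CC4)cc3)nc2n1C1CCCC1`: -0.4%
- compound 3 `Cc1ccc(NC(=O)C2(C(=O)Nc3ccc(Nc4ncc5cc(C(=O)N(C)C)n(C6CCCC6)c5n4)cc3)CC2)cc1`: 99.6%

These numbers come from a functional assay on T47D cells (Homo sapiens) for inhibition, read by CCK-8 assay, with a stated time of 72 h, tested at 10 uM; on this read-out lower numbers stand for less inhibition of growth and higher numbers for more inhibition of growth at the one concentration tested. Of the three, compound 2 stands lowest, at -0.4%. Compound 4 `CN(C)C(=O)c1cc2cnc(Nc3ccc(NC(=O)C4(C(=O)Nc5cccc(C(F)(F)F)c5)CC4)cc3)nc2n1C1CCCC1` differs from compound 2 in one place: trifluoromethyl in place of fluoro on an aromatic carbon. Among the compounds with values here, only one measured step bears on this aromatic ring, the swap of 3-fluorophenyl for 4-methylphenyl, and it was a number 100 percentage points higher from compound 2 to compound 3 (beyond the scatter). That swap brings a different group at a different place, so it shows that large changes are possible here but does not fix the direction for compound 4. A rise smaller than that step is expected, with wide uncertainty. The expected step is a number 40.4 percentage points higher from compound 2 to compound 4 (beyond the scatter). For compound 4 the estimated value is 40%, with an expected range of 0% to 95%.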

Compound 4, percent growth inhibition at one concentration: 92.7%
Beside the measured number, compound 4's estimate is 52.7 percentage points below it, and the stated range covers the measured number.
By their numbers in this assay, from the lowest: compound 2; then compound 1; then compounds 4 and 3 (each within the scatter of the next).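

In this assay, trifluoromethyl in place of fluoro on the same aromatic carbon is enough on its own to turn an inactive compound into a strong growth inhibitor (a number 93.1 percentage points higher from compound 2 to compound 4 (beyond the scatter)). The result also shows that a second group can do this: 3-(trifluoromethyl)phenyl and 4-methylphenyl cannot be told apart here (a number 6.9 percentage points lower from compound 3 to compound 4 (within the scatter)), leaving 3-fluorophenyl as the one that stands apart. Nothing available explains why fluoro and trifluoromethyl differ so sharply. From the compounds shown here alone, it remains open whether a chloro, methoxy or amino group at this place would behave like fluoro or like trifluoromethyl.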